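The compounds below may be only part of what the source reports. "The series", "measured", "known", "first", "only" and "open" are said of these compounds alone.

Measured in a functional assay on KB cells (Homo sapiens) for cytotoxicity; on this read-out lower numbers stand for stronger inhibition and higher numbers for weaker inhibition:
- compound 1 `CCOCn1cc(C#N)c2c(N)ncnc21`: > 100000 nM (a limit)
- compound 2 `CCOCn1cc(C(N)=O)c2c(N)ncnc21`: > 100000 nM (a limit)
- compound 3 `CCOCn1cc(C(=N)S)c2c(N)ncnc21`: 68000 nM

For the measured compounds named here, compound 3 has the only actual number of the three, while the other two sit at the limit of > 100000 nM in this assay, at which 2 of the 3 values shown sit. Compound 4 `Cc1cccc(Cn2cc(C(=N)S)c3c(N)ncnc32)c1` differs from compound 3 in one group: 3-methylphenyl in place of ethoxy on a saturated chain carbon bound to an aromatic nitrogen. In short, 3-methylphenyl stands in place of ethoxy on a saturated chain carbon bound to an aromatic nitrogen.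

The measured steps all change a different group, on an aromatic carbon. They are an at least 1.4-fold lower number from compound 1 to compound 3 (0.16 log units; that floor lies within the scatter) and an at least 1.4-fold lower number from compound 2 to compound 3 (0.16 log units; that floor lies within the scatter), along with a step that the two limits leave unreadable from compound 1 to compound 2. None of them touches the place that changes now, so none offers a size to carry over. No step beyond the scatter is therefore expected in this assay, and no direction can be favoured. The expectation stays anchored on compound 3 at 68000 nM, with a wide range.

The expected change is a 1.5-fold lower number from compound 3 to compound 4 (0.18 log units; within the scatter). For compound 4 the estimated value is 45000 nM, with an expected range from 8000 nM to 150000 nM.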

Compound 4, half-maximal inhibitory concentration: 30000 nM
Compound 4: the middle estimate sits 1.5-fold (0.18 log units) above what was measured; the range from low to high includes it.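

In this assay, changing the group on the saturated chain carbon bound to an aromatic nitrogen gives a 2.3-fold lower number from compound 3 to compound 4 (0.36 log units; beyond the scatter). For the compounds shown here, this is the first step at this place, and it shows that the read-out responds modestly when 3-methylphenyl, with its six-membered aromatic ring of carbon only, stands in place of ethoxy. The earlier steps all changed a group on an aromatic carbon, and two of the earlier values are limits rather than numbers: the limit of > 100000 nM in this assay, at which 2 of the 4 values shown sit.

The compounds shown leave open whether the ring itself or its methyl group accounts for this step, as a plain phenyl group does not appear among them. They also leave open how an amine or a longer chain would read at this place.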